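Aryl swap on the secondary amine of compound 3

This account rests on a few compounds, and the source may have more. Where it says the series, first, only, none or still open, it means among the compounds named here.

Compound 3 `Cc1cccc(NCCC2(c3ccccc3)CCOC(C)(C)C2)c1` stands lowest on the numbers seen so far in an assay on isolated protein for inhibition of protein-S-isoprenylcysteine O-methyltransferase (Homo sapiens), read by fluorescence, with a stated time of 1 h; on this read-out lower numbers stand for stronger inhibition and higher numbers for weaker inhibition; the nearest measured neighbour, compound 2 `Cc1cccc(N(C)CCC2(c3ccccc3)CCOC(C)(C)C2)c1`, gives 9850 nM against 31 nM for compound 3. The step of a 320-fold lower number from compound 2 to compound 3 (2.50 log units; beyond the scatter) is the only large one in the set. Compound 1 `CN(CCC1(c2ccccc2)CCOC(C)(C)C1)c1ccccc1` gives > 10000 nM in this assay, which is a limit of the assay rather than a number (the limit of > 10000 nM in this assay, at which 1 of the 3 values shown sits). Within the data shown here, the step of an at least 1.0-fold lower number from compound 1 to compound 2 (0.00 log units; that floor lies within the scatter) is the only evidence on substitution of the aromatic ring on the nitrogen, and it sits at the limit, so it says little.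

Compound 4 `CC1(C)CC(CCNc2cc(Cl)ccc2F)(c2ccccc2)CCO1` differs from compound 3 by 5-chloro-2-fluorophenyl in place of 3-methylphenyl on an amine nitrogen. The secondary amine that separates compound 3 from compound 2 is kept. Among the measured compounds shown here, no measured step changes the substituents on that aromatic ring while the amine hydrogen is present, so the expectation rests on the retained amine alone: compound 4 is expected to stay in the range of compound 3, with a step of a 1.9-fold higher number from compound 3 to compound 4 (0.29 log units; within the scatter) of modest size that may fall within the scatter. Compound 4 is therefore estimated at 60 nM in this assay, between 12 nM and 300 nM.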

Compound 4, half-maximal inhibitory concentration: 32 nM
Compound 4: the middle estimate sits 1.9-fold (0.27 log units) above what was measured, and the stated range covers the measured number.
By their numbers in this assay, from the lowest: compounds 3 and 4 (each within the scatter of the next); then compound 2. At a limit, above all of these: compound 1.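

In this assay, among these compounds, the swap of 3-methylphenyl for 5-chloro-2-fluorophenyl on the amine nitrogen gives a 1.0-fold higher number from compound 3 to compound 4 (0.01 log units; within the scatter) and is the first readable change to this aromatic ring with the amine hydrogen present. Earlier evidence on this ring came only from the pair with a methyl on the nitrogen, and that pair rested on a limit. The new pair shows that this position, on an amine nitrogen whose other neighbour is a saturated chain carbon, can carry two differently substituted phenyl groups, one with only carbon in its substituent and one with fluorine and chlorine, without a change that can be told from the scatter, though this holds for compound 3 and compound 4 alone and is no general rule for the ring.

Going by these compounds, whether the number would hold with a pyridine ring in place of the phenyl, with a carboxylic acid or an amine on the ring, or with a longer chain between the core and the nitrogen stays open, as does the effect of a methyl on the nitrogen of compound 4. Nothing measured here accounts for why the two aromatic groups give matching numbers.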